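Glycine amide series, tail flick: adding a hydroxymethyl

The compounds below may be only part of what the source reports. "The series", "measured", "known", "first", "only" and "open" are said of these compounds alone.

Compound 1 `O=C(CN(c1nc(Cl)nc2[nH]cnc12)C1CC1)NCC(=O)OCc1ccccc1` is assayed in a functional assay on the whole organism (Tail, strain ICR) with Mus musculus as the target, in the tail flick test, with a stated time of 90 min, at a dose of 25 umol/kg by the oral route (on this read-out lower numbers stand for a weaker effect and higher numbers for a stronger effect at the one dose given), where compound 1 gives 27.2%. Two further members share the read-out: compound 2 `C[C@H](NC(=O)CN(c1ncnc2c1ncn2C1CCCCO1)C1CC1)C(=O)OCc1ccccc1` gives 32.1%, and compound 3 `O=C(O)C[C@H](NC(=O)CN(c1nc(Cl)nc2[nH]cnc12)C1CC1)C(=O)O` gives 25.1%. Compound 1 thus stands second highest of the three numbers, but its gaps to both others lie within the scatter, so no ordering is claimed. Compound 4 `O=C(CN(c1nc(Cl)nc2[nH]cnc12)C1CC1)N[C@@H](CO)C(=O)OCc1ccccc1` is the next member to be measured. It differs from compound 1 in one place: hydroxymethyl in place of hydrogen on a saturated chain carbon bound to an amide-type nitrogen and a carbonyl carbon. For the measured compounds named here, no step between measured compounds calibrates this change; the three numbers seen so far lie close together, so the step is expected to be small, in no particular direction, and not beyond the scatter. The estimated step in this assay is a number 0.8 percentage points higher from compound 1 to compound 4 (within the scatter). Compound 4 is accordingly expected to give about 28%, within 18% to 38%.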

Compound 4, a percentage reported as activity, at one dose (the size of the read-out at that dose, not a potency): 34.5%
Beside the measured number, compound 4's estimate is 6.5 percentage points below it, and the stated range covers the measured number.
By their numbers in this assay, from the lowest: compounds 3, 1, 2 and 4 (each within the scatter of the next).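

In this assay, hydroxymethyl in place of hydrogen on a saturated chain carbon bound to an amide-type nitrogen and a carbonyl carbon gives a number 7.3 percentage points higher from compound 1 to compound 4 (within the scatter), the first one-place step read in this series. This position therefore accepts the hydroxymethyl with the read-out kept within the scatter, so no gain can be claimed. Nothing available explains the size of this step.

Going by these compounds, whether a carboxylic acid or an amine on a longer chain at this carbon would move the number beyond the scatter remains open.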